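Replacing a Phenyl Ring with a Thiazole

A few compounds are considered here, and "the series" means these few. Any claim that something is new, unique, unknown or untested is made for them only; others in the source may bear on it.

- compound 1 `O=C(Nc1ccc(-c2cscn2)cc1)[C@H]1CCCN(Cc2ccc(F)c(F)c2)C1` gives 190 nM here
- compound 2 `O=C(Nc1ccc(-c2cscn2)cc1)C1CCCN(Cc2cc(F)c(F)c(F)c2)C1` gives 400 nM here
- compound 3 `O=C(Nc1ccc(-c2ccccc2)cc1)C1CCCN(Cc2ccc(F)c(F)c2)C1` gives 2580 nM here

All three values come from a functional assay on A-375 cells (Homo sapiens) for antiproliferative activity (a lower number here means a stronger inhibitor, a higher number a weaker inhibitor), and together they form a small set. Compound 3, at 2580 nM in this measure, has the highest number of the three and is therefore the weakest inhibitor, clearly beyond the usual scatter of repeat measurements. The next compound to consider is compound 4 `O=C(Nc1ccc(-c2nccs2)cc1)C1CCCN(Cc2ccc(F)c(F)c2)C1`, which has not yet been measured. It keeps the core of compound 3, but 1,3-thiazol-2-yl stands in place of phenyl on an aromatic carbon, para to a large group: 1,3-thiazol-2-yl in place of phenyl on an aromatic carbon is the full count of that change.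

Going by the values given here, no measured pair shows this swap alone. Still, compound 1 at 190 nM and compound 2 at 400 nM both carry a thiazole where compound 3 has phenyl, and both have much lower numbers. Their thiazole is attached differently, however, so the gain may not carry over in full. A clear move toward stronger inhibition is therefore expected, with an estimated change of a 4.7-fold lower number from compound 3 to compound 4 (0.67 log units; beyond the scatter) in this assay as the likely size. Compound 4 is estimated at 550 nM (expected range 150 nM to 2000 nM).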

Compound 4, half-maximal inhibitory concentration: 240 nM
Estimate against measurement, compound 4: 2.3-fold (0.36 log units) above; the range from low to high includes it.
By their numbers in this assay, from the lowest: compounds 1, 4 and 2 (each within the scatter of the next, the first and the last beyond it); then compound 3.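

Compound 3 and compound 4 differ only in the ring on an aromatic carbon, para to a large group, so this pair isolates the effect of the swap: in this assay, 1,3-thiazol-2-yl in place of phenyl gives an 11-fold lower number from compound 3 to compound 4 (1.03 log units; beyond the scatter). The earlier compounds shown here could only hint at this, since each carried its thiazole attached differently and none formed a pair with compound 3 that differed in one place. The change replaces a six-membered ring of carbon only, with 0 hydrogen-bond acceptors, by a five-membered ring with 2 hetero atoms and 2 hydrogen-bond acceptors, but no data here explain which of these differences matters to the antiproliferative result.

The compounds shown leave open whether this position needs the sulfur and nitrogen of the thiazole, as a matched oxazol-2-yl ring, with oxygen in place of sulfur, or a pyridin-2-yl ring could help to show. They also leave open whether the same swap would give a step of similar size with a different group on the far side of the molecule, such as a plain benzyl group without fluorine.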